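Fluoro for hydrogen on the phenyl group of compound 3

A few compounds are considered here, and "the series" means these few. Any claim that something is new, unique, unknown or untested is made for them only; others in the source may bear on it.

Measured compounds:
compound 1, `CN(Cc1cc(C(F)(F)F)cc(C(F)(F)F)c1)C(=O)c1c(-c2ccc(F)cc2)c2cccnc2c(=O)n1C`, 0.21 nM
compound 2, `CN(Cc1cc(C(F)(F)F)cc(C(F)(F)F)c1)C(=O)c1c(-c2ccccc2)c2cccnc2c(=O)n1C`, 0.25 nM
compound 3, `CN(Cc1ccccc1)C(=O)Nc1c(-c2ccccc2)c2ccccc2c(=O)n1C`, 110 nM

All three were run in an assay on IM-9 cells for binding affinity to Substance-P receptor (Homo sapiens); a higher number here means a weaker inhibitor, a lower number a stronger inhibitor. Compound 1 and compound 2 share one core and differ by fluoro in place of hydrogen on an aromatic carbon; the step of a 1.2-fold lower number from compound 2 to compound 1 (0.08 log units; within the scatter) is small and within the scatter, so the two values cannot be ordered. Compound 3 carries a different core, and how the two cores differ is not broken down here; the values alone show that in this assay compound 3 gives 110 nM, far beyond the scatter away from both compound 1 and compound 2.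

Compound 4, `CN(Cc1ccccc1)C(=O)Nc1c(-c2ccc(F)cc2)c2ccccc2c(=O)n1C`, is not yet measured. It differs from compound 3 by fluoro in place of hydrogen on an aromatic carbon, the same change as from compound 2 to compound 1, made on the same place, the phenyl group of the core. For the measured compounds named here, in the one measured example this change moved the number only within the scatter. Going by the values given here, with no second example, the expectation for compound 4 rests on that single step: the step from compound 3 to compound 4 in this assay is expected to be about a 1.2-fold lower number from compound 3 to compound 4 (0.06 log units; within the scatter), again within the scatter, because of a 1.2-fold lower number from compound 2 to compound 1 (0.08 log units; within the scatter). Compound 4 is thus expected to give roughly 95 nM in this assay, with a range of about 45 nM to 200 nM allowing for the change acting differently on the core of compound 3 than on that of compound 2.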

Compound 4, half-maximal inhibitory concentration: 1500 nM
Compound 4: the middle estimate sits 16-fold (1.20 log units) below what was measured; the measured number lies above the stated range.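

In this assay, the change from phenyl to 4-fluorophenyl does not carry over as one fixed step between the two cores in this series: the same change on two cores in this assay, a 1.2-fold lower number (0.08 log units; within the scatter) from compound 2 to compound 1 and a 14-fold higher number (1.13 log units; beyond the scatter) from compound 3 to compound 4, 16-fold (1.21 log units) apart, beyond the scatter of two such steps On the core of compound 3 the step reads a 14-fold higher number from compound 3 to compound 4 (1.13 log units; beyond the scatter), so fluoro in place of hydrogen there gives a clearly weaker inhibitor, while on the other core the values cannot be ordered. For the compounds shown here, this rests on only two matched pairs, and the two cores differ in more than one place, so the pairs do not show which difference separates the steps, why they part, or how the change would behave on any further core.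

The compounds shown leave open whether chloro or methoxy at the same place on the core of compound 3 would give a step like that of fluoro, or whether this large step is particular to fluoro. Also open, on these data alone, is whether the step would stay this large with trifluoromethyl groups on the benzyl group of compound 3, which would bring that part of the molecule closer to compound 1 and compound 2.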